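Nitro in Place of Cyano: Expecting Little Change

A few compounds are considered here, and "the series" means these few. Any claim that something is new, unique, unknown or untested is made for them only; others in the source may bear on it.

Of the compounds shown here, three sharing one core have been measured. Compound 1 `COc1ccc(C(N)=O)cc1/C=C/c1ccc(C(C)(C)C)cc1` carries a tert-butyl group and in an ADME assay on HCT-116 cells (Homo sapiens) for antiproliferative activity (on this read-out higher numbers stand for weaker inhibition and lower numbers for stronger inhibition), compound 1 gives 20000 nM. Compound 2 `COc1ccc(C(N)=O)cc1/C=C/c1ccc(F)cc1` carries fluoro instead, and compound 2 gives 24000 nM. Compound 3 `COc1ccc(C(N)=O)cc1/C=C/c1ccc(C#N)cc1` carries cyano, and compound 3 gives 16000 nM. Among the compounds with values here, compound 3 shows the lowest of the three numbers, but its steps to the others are small, a 1.3-fold lower number from compound 1 to compound 3 (0.10 log units; within the scatter) and a 1.5-fold lower number from compound 2 to compound 3 (0.18 log units; within the scatter), so no compound can be called stronger than another. The change to compound 4 `COc1ccc(C(N)=O)cc1/C=C/c1ccc([N+](=O)[O-])cc1` is nitro in place of cyano on an aromatic carbon, on an aromatic carbon of a six-membered aromatic ring of carbon only, para to a large group. All three measured steps bear on it, since each exchanges the group at this same place: a 1.2-fold higher number from compound 1 to compound 2 (0.08 log units; within the scatter), a 1.3-fold lower number from compound 1 to compound 3 (0.10 log units; within the scatter) and a 1.5-fold lower number from compound 2 to compound 3 (0.18 log units; within the scatter). Each stayed within the scatter, so no step beyond the scatter is expected here either. Compound 4 is therefore estimated at 16000 nM, with a range from 8000 nM to 32000 nM. The expected step is no change at the digits printed from compound 3 to compound 4 (within the scatter).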

Compound 4, half-maximal inhibitory concentration: 22000 nM
Compound 4: middle estimate off by 1.4-fold (0.14 log units), on the low side; low and high end bracket the measured number.
By their numbers in this assay, from the lowest: compounds 3, 1, 4 and 2 (each within the scatter of the next).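

In this assay, nitro is a fourth group at this one place on the aromatic ring, and it gives a 1.4-fold higher number from compound 3 to compound 4 (0.14 log units; within the scatter) and a 1.1-fold lower number from compound 2 to compound 4 (0.04 log units; within the scatter) and also a 1.1-fold higher number from compound 1 to compound 4 (0.04 log units; within the scatter) in the comparisons with the three earlier groups. All six exchanges among tert-butyl, fluoro, cyano and nitro now stay within the scatter, a wider set of comparisons than the three available before. On this read-out, therefore, these four groups cannot be told apart at this place.

On these data alone, whether an amine, a carboxylic acid or a longer chain here would move the number beyond the scatter stays open, as does the effect of changes elsewhere on the shared core. Why these four groups read alike also stays open, and no supporting measurement bears on it.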